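A few compounds are considered here, and "the series" means these few. Any claim that something is new, unique, unknown or untested is made for them only; others in the source may bear on it.

Compound 1 `CCOc1ccc(CN(Cc2ccc(C(C)(C)C)cc2)Cc2cc3cc(C)ccc3[nH]c2=O)cc1`, in a toxicity assay on MDCK cells (Canis lupus familiaris) for cytotoxicity, read by crystal violet staining, with a stated time of 48 h; a lower number here means that less compound is tolerated, a higher number that more compound is tolerated: > 10000 nM, a limit.
Compound 2 `Cc1ccc2[nH]c(=O)c(CN(Cc3ccc(OC(C)C)cc3)Cc3ccc(C(C)(C)C)cc3)cc2c1`, in this assay: > 5000 nM, a limit.

Compound 2 therefore stands only at a limit in this assay, and the other value shown is a limit as well (the limit of > 10000 nM in this assay, at which 1 of the 2 values shown sits; (the limit of > 5000 nM in this assay, at which 1 of the 2 values shown sits)). Within the data shown here, the single measured step, a step that the two limits leave unreadable from compound 1 to compound 2, gives no readable size. Compound 3 `CCCCOc1ccc(CN(Cc2ccc(C(C)(C)C)cc2)Cc2cc3cc(C)ccc3[nH]c2=O)cc1` differs from compound 2 by butyl in place of isopropyl on an oxygen on an aromatic ring. Among the measured compounds shown here, no measured step speaks to this change, so in this assay no shift beyond the scatter is expected; the expected step is a step that the limit leaves unreadable from compound 2 to compound 3. Compound 3 is accordingly estimated at 10000 nM, within 5000 nM to 30000 nM, and will probably again be reported only as a limit.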

Compound 3, half-maximal cytotoxic concentration: > 5000 nM
Compound 3: no number, only a limit (the forecaster's own chance of this, stated with the estimate: 80%); the middle value lies beyond the limit too.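

Compound 3 also gives only a limit in this assay, so its steps from compound 1 and compound 2 cannot be read. The compounds shown leave open whether butyl in place of isopropyl shifts the tolerated concentration at all.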